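This account rests on a few compounds, and the source may have more. Where it says the series, first, only, none or still open, it means among the compounds named here.

Going by the values given here, compound 1 `CC1=C(C(=O)OC(C(F)(F)F)C(F)(F)F)C(c2ccoc2)NC(=O)N1` is the one compound here with a single number in an assay on HEK293 cells for displacement of a labelled ligand from adenosine receptor A2b (Homo sapiens), read by radioligand binding, with a stated time of 30 min, tested at 1 uM; on this read-out lower numbers stand for less inhibition and higher numbers for more inhibition at the one concentration tested (going by the name of the read-out): compound 1 gives 2%, a weak effect at the tested concentration. Compound 2 `CC1=C(C(=O)OC(C)C(F)(F)F)C(c2cccs2)NC(=O)N1` shows similarly little, with 1%; 4% (2 entries) across its entries (the several entries of compound 2 in this assay, 1%; 4% (2 entries)). Compound 3 `CC1=C(C(=O)OC(C)C(F)(F)F)C(c2ccoc2)NC(=O)N1` has not yet been tested. It differs from compound 1 by methyl in place of trifluoromethyl on a saturated chain carbon bound to an oxygen next to a carbonyl group and a saturated chain carbon. With both measured compounds near the bottom of the scale, the step of a number 1 percentage points higher from compound 1 to compound 3 (within the scatter) is expected to stay within the usual scatter, in no clear direction. Compound 3 is therefore estimated to give 3%, between -5% and 12%.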

Compound 3, a percentage reported as inhibition, at one concentration (the size of the read-out at that concentration, not a potency): 23%
For compound 3 the middle estimate is 20 percentage points below the measured one, and the stated range ends below it.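

At the saturated chain carbon bound to an oxygen next to a carbonyl group and a saturated chain carbon, the choice of group matters: in this assay, methyl in place of trifluoromethyl gives a number 21 percentage points higher from compound 1 to compound 3 (beyond the scatter). This methyl does not bring such a signal in every compound, as compound 2 also holds it, differs from compound 3 only in its ring, and still stays low: the several entries of compound 2 in this assay, 1%; 4% (2 entries)

Which part of the trifluoromethyl group accounts for the step remains open. So does whether an ethyl group or an amine at this carbon would raise the signal further.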